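Pyrazole amide series: swapping the benzyl amide substituent

A few compounds are considered here, and "the series" means these few. Any claim that something is new, unique, unknown or untested is made for them only; others in the source may bear on it.

Of the compounds shown here, three sharing one core have been measured in an assay on microsomes from liver for inhibition of 3-hydroxy-3-methylglutaryl-coenzyme A reductase (Rattus norvegicus); on this read-out lower numbers stand for stronger inhibition and higher numbers for weaker inhibition. Compound 1 `CC(C)c1c(C(=O)N(C)Cc2ccccc2)nn(-c2ccc(F)cc2)c1OC[C@@H](O)C[C@@H](O)CC(=O)O` gives 5.2 nM in this assay, and compound 2 `CC(C)c1c(C(=O)NCc2cccc(F)c2F)nn(-c2ccc(F)cc2)c1OC[C@@H](O)C[C@@H](O)CC(=O)O` gives 2 nM. Compound 3 `Cc1ccc(CN(C)C(=O)c2nn(-c3ccc(F)cc3)c(OC[C@@H](O)C[C@@H](O)CC(=O)O)c2C(C)C)cc1` gives 37 nM, the highest number of the three, with compound 1 nearest and compound 2 furthest from it.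

The step to compound 4 `Cc1cccc(CNC(=O)c2nn(-c3ccc(F)cc3)c(OC[C@@H](O)C[C@@H](O)CC(=O)O)c2C(C)C)c1` is (3-methylbenzyl)amino in place of methyl(4-methylbenzyl)amino on a carbonyl carbon. Within the data shown here, two measured steps bear on it. The step of a 7.1-fold higher number from compound 1 to compound 3 (0.85 log units; beyond the scatter) shows that a methyl on the aromatic carbon of the benzyl group raised the number; compound 4 still carries a methyl, though on a different position of that ring. The step of a 2.6-fold lower number from compound 1 to compound 2 (0.41 log units; beyond the scatter) shows that exchanging benzyl(methyl)amino for an amino group bearing only hydrogen lowered the number, albeit with fluorines also entering. The step of a 19-fold higher number from compound 2 to compound 3 (1.27 log units; beyond the scatter) combines both changes in the opposite direction. Since compound 4 drops the methyl on nitrogen while keeping a methyl on the ring, a modest to large decrease in this assay is expected, a 6.2-fold lower number from compound 3 to compound 4 (0.79 log units; beyond the scatter). Compound 4 is therefore estimated at 6 nM, within a range from 2 nM to 18 nM.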

Compound 4, half-maximal inhibitory concentration: 4.9 nM
For compound 4 the middle estimate is 1.2-fold (0.09 log units) above the measured one, within the range that was stated.
By their numbers in this assay, from the lowest: compound 2; then compounds 4 and 1 (each within the scatter of the next); then compound 3.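

In this assay, the step of a 7.6-fold lower number from compound 3 to compound 4 (0.88 log units; beyond the scatter) shows that a methyl-bearing benzyl group on this carbonyl carbon does not always come with a high number: (3-methylbenzyl)amino, which brings in the amide hydrogen, reads far lower than methyl(4-methylbenzyl)amino. The step of a 1.1-fold lower number from compound 1 to compound 4 (0.03 log units; within the scatter) lies within the scatter, so (3-methylbenzyl)amino and the unsubstituted benzyl(methyl)amino cannot be told apart in this assay, even though they differ in both the ring methyl and the methyl on nitrogen. Among these compounds, with the amide hydrogen present in both compounds, the step of a 2.5-fold higher number from compound 2 to compound 4 (0.39 log units; beyond the scatter) gives the first comparison of ring substituents alone, and here 3-methylphenyl reads higher than 2,3-difluorophenyl, by a margin beyond the scatter.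

On these data alone, the step from compound 3 to compound 4 moves the ring methyl and removes the methyl on nitrogen together, so the share of each remains open, as does how (4-methylbenzyl)amino or a benzyl group carrying a methoxy or a chlorine would read at this carbonyl carbon. Nothing available here gives a reason for any of these steps.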